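A few compounds are considered here, and "the series" means these few. Any claim that something is new, unique, unknown or untested is made for them only; others in the source may bear on it.

Compound 1 `COCCC(=O)Nc1cnc(NCc2c(F)ccc3c2CCO3)n2cnnc12` is the starting point. In an ADME assay on microsomes from liver (Homo sapiens) for metabolic stability, read by LC-MS, using NADPH, with stated times of 5 min and 30 min, tested at 1 uM (a higher number here means faster removal of the compound, a lower number slower removal), compound 1 gives < 3 mL.min-1.g-1, which is a limit of the assay rather than a number, as noted in the limit of < 3 mL.min-1.g-1 in this assay, at which 1 of the 3 values shown sits. Two other compounds give numbers. Compound 2 `CN(C)Cc1ccc(C(=O)Nc2cnc(NCc3c(F)ccc4c3CCO4)n3cnnc23)cc1` gives 13 mL.min-1.g-1 in this assay, and compound 3 `Cc1ncc(-c2cnc(NCc3c(F)ccc4c3CCO4)c3cn[nH]c(=O)c23)n1C` gives 10 mL.min-1.g-1. Compound 4 `Fc1ccc2c(c1CNc1ncc(Nc3ccccc3)c3nncn13)CCO2` has not yet been measured. It differs from compound 1 in one place: phenyl in place of (2-methoxyethyl)carbonyl on a nitrogen on an aromatic ring. Going by the values given here, the only measured step that starts from compound 1 is an at least 4.3-fold higher number from compound 1 to compound 2 (0.63 log units; beyond the scatter), in which a substituted phenyl entered on the carbonyl carbon and the number rose clearly beyond the scatter; its full size cannot be told, as compound 1 sits at a limit. In compound 4 a phenyl enters as well, but the carbonyl itself leaves, so that step is only a loose guide. A rise from the limit is still the more likely outcome for compound 4, and a modest one is expected. The expected step is an at least 4.0-fold higher number from compound 1 to compound 4 (0.60 log units; beyond the scatter). Compound 4 is therefore estimated at 12 mL.min-1.g-1 in this assay, with a plausible range from 4 mL.min-1.g-1 to 35 mL.min-1.g-1.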

Compound 4, intrinsic clearance in microsomes: 20 mL.min-1.g-1
Compound 4: middle estimate off by 1.7-fold (0.22 log units), on the low side; the measured number falls inside the stated range.
By their numbers in this assay, from the lowest: compounds 3, 2 and 4 (each within the scatter of the next). At a limit, below all of these: compound 1.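

Putting phenyl in place of (2-methoxyethyl)carbonyl on this nitrogen gives an at least 6.6-fold higher number from compound 1 to compound 4 (0.82 log units; beyond the scatter) in this assay. The earlier step at this place kept the carbonyl, whereas here the carbonyl leaves along with the chain, and the number still rises beyond the scatter; compound 2 gives 13 mL.min-1.g-1 and compound 4 gives 20 mL.min-1.g-1, values within the scatter of each other, so a plain phenyl without the carbonyl or the dimethylaminomethyl group lands in the same range. The full size of the step cannot be read, as compound 1 gives a limit of the assay and not a number: the limit of < 3 mL.min-1.g-1 in this assay, at which 1 of the 4 values shown sits.

Compound 4 changes two things at once, losing the carbonyl and gaining an aromatic ring, so the compounds shown do not tell which of the two goes with the higher number. A short alkyl chain such as ethyl on this nitrogen would take away the carbonyl without adding a ring, and a phenyl bearing a carboxylic acid or a methoxy group would show whether the number at this place moves with what the ring carries.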